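Amine head-group variation, compounds 1 to 3

The compounds below may be only part of what the source reports. "The series", "measured", "known", "first", "only" and "open" are said of these compounds alone.

Measured so far:
compound 1 `O=c1cc(-c2ccccc2)oc2cc(OCc3ccccc3)c(OCCCN3CCCCC3)c(O)c12` gives 3100 nM in a functional assay on A549 cells (Homo sapiens) for antiproliferative activity, read by MTT assay, with a stated time of 48 h; a lower number here means a stronger inhibitor, a higher number a weaker inhibitor
compound 2 `CN1CCN(CCCCOc2c(OCc3ccccc3)cc3oc(-c4ccccc4)cc(=O)c3c2O)CC1` gives 4400 nM in this assay

Compound 2 carries the higher of the two numbers, but the step of a 1.4-fold higher number from compound 1 to compound 2 (0.15 log units; within the scatter) is within the scatter, so the two compounds cannot be ordered on these data. Compound 3 `CN(C)CCCOc1c(OCc2ccccc2)cc2oc(-c3ccccc3)cc(=O)c2c1O` is not yet measured; it differs from compound 2 by dimethylamino in place of (4-methylpiperazin-1-yl)methyl on a saturated chain carbon, three bonds along the chain from an oxygen on an aromatic ring. Going by the values given here, the only measured step that bears on this, a 1.4-fold higher number from compound 1 to compound 2 (0.15 log units; within the scatter), also exchanged the amine at the same place on the chain and produced no change beyond the scatter. Compound 3 trims that amine further, and nothing measured here points to a direction, so the expected step of a 1.2-fold lower number from compound 2 to compound 3 (0.06 log units; within the scatter) is none beyond the scatter. Compound 3 is therefore estimated at 3800 nM, with a range of 1500 nM to 9000 nM in this assay.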

Compound 3, half-maximal inhibitory concentration: 2600 nM
The estimate for compound 3 lay 1.5-fold (0.16 log units) above the measured number; the measured number falls inside the stated range.
By their numbers in this assay, from the lowest: compounds 3, 1 and 2 (each within the scatter of the next).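

With compound 3, the amine at this place has now been exchanged for one with no ring, and the number still does not separate in this assay: the exchange gives a 1.7-fold lower number from compound 2 to compound 3 (0.23 log units; within the scatter) and, against the piperidin-1-yl head group, a 1.2-fold lower number from compound 1 to compound 3 (0.08 log units; within the scatter) on the same chain. Across dimethylamino, piperidin-1-yl and 4-methylpiperazin-1-yl, the three compounds therefore show that neither the size of the amine nor the presence of a ring sets this read-out apart, and the 3-(dimethylamino)propyl to 4-(4-methylpiperazin-1-yl)butyl difference adds nothing beyond the scatter either. No measurement shown here offers an explanation for this flat result.

Going by these compounds, whether morpholin-4-yl, a primary amine or a carboxylic acid at this place would give a step beyond the scatter remains open. So does the effect of a longer chain carrying dimethylamino.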